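A few compounds are considered here, and "the series" means these few. Any claim that something is new, unique, unknown or untested is made for them only; others in the source may bear on it.

Compound 1 `Cn1nc(C(F)(F)F)c2c(-c3ccccc3)cc(NNC(=O)Nc3cc(Cl)nc(Cl)c3)nc21`: 13100 nM
Compound 2 `Cc1nn(C)c2nc(NNC(=O)Nc3cc(Cl)nc(Cl)c3)cc(-c3ccccc3)c12`: 22900 nM

Both compounds were tested in a functional assay on SW620/5-FU cells (Homo sapiens) for cytotoxicity, read by MTT assay, with a stated time of 48 h, in the presence of a further agent that is not named here; a lower number here means that less compound is needed, a higher number that more compound is needed for the effect. Compound 1, at 13100 nM, holds the lower of the two numbers, but compound 2 is not separated from it: a 1.7-fold higher number from compound 1 to compound 2 (0.24 log units; within the scatter). Compound 3 `CCCc1cc(NNC(=O)Nc2cc(Cl)nc(Cl)c2)nc2c1c(C(F)(F)F)nn2C` carries propyl in place of phenyl on an aromatic carbon, opposite the ring nitrogen: propyl in place of phenyl on an aromatic carbon. Among the measured compounds shown here, the only measured step, a 1.7-fold higher number from compound 1 to compound 2 (0.24 log units; within the scatter), replaces trifluoromethyl elsewhere and keeps the phenyl, so it bears only indirectly. For the measured compounds named here, no measured step covers this change, so no step beyond the scatter in this assay can be expected with confidence, and the direction stays open. The expected step is a 1.4-fold higher number from compound 1 to compound 3 (0.14 log units; within the scatter). Compound 3 is estimated at 18000 nM, within an expected range of 6000 nM to 50000 nM.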

Compound 3, half-maximal effective concentration: 11700 nM
Compound 3: the middle estimate sits 1.5-fold (0.19 log units) above what was measured, and the stated range covers the measured number.
By their numbers in this assay, from the lowest: compounds 3, 1 and 2 (each within the scatter of the next).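

Replacing phenyl with propyl on this aromatic carbon, opposite the ring nitrogen, gives a 1.1-fold lower number from compound 1 to compound 3 (0.05 log units; within the scatter) in this assay and so leaves compound 1 and compound 3 inseparable. On this core, with trifluoromethyl kept, the six-membered aromatic ring at this position is therefore not needed for a number of this size. Nothing available explains this outcome. From the compounds shown here alone, whether an amine, a carboxylic acid or a longer chain at this position would move the number beyond the scatter stays open. So does whether propyl behaves the same way with methyl in place of trifluoromethyl.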